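Replacing the propoxycarbonyl group of compound 2

The source may hold more compounds than are shown below. What is called first, only, known or untested is meant among the compounds shown, and "the series" means these compounds.

Of the compounds shown here, two have numbers so far in a functional assay on RAW264.7 cells (Mus musculus), read by fluorescence (on this read-out lower numbers stand for stronger inhibition and higher numbers for weaker inhibition), on record. Compound 1 (`CCOC(=O)C1=CCCCC1SCc1ccc(F)cc1Cl`) reads 5650 nM and compound 2 (`CCCOC(=O)C1=CCCCC1S(=O)(=O)Cc1ccc(F)cc1Cl`) reads 14 nM in this series, which makes compound 2 the lower of the two, well beyond the scatter. The pair differs in more than one place, so the gap belongs to no single change.

Compound 3 (`CCC(O)C1=CCCCC1S(=O)(=O)Cc1ccc(F)cc1Cl`) carries 1-hydroxypropyl in place of propoxycarbonyl on a double-bonded ring carbon. Among the measured compounds shown here, no measured pair tests this place, so the expectation is a judgement without direct support. Weaker inhibition is expected in this assay with a rise in the number beyond the scatter. The expected size is a 36-fold higher number from compound 2 to compound 3 (1.55 log units; beyond the scatter) with wide uncertainty. For compound 3 the estimated value is 500 nM with an expected range from 60 nM to 4000 nM in this read-out.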

Compound 3, half-maximal inhibitory concentration: > 10000 nM
Compound 3: only a limit was reported (the forecaster's own chance of this, stated with the estimate: 15%); middle value at least 20-fold (1.30 log units) away from the limit.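

Among the compounds shown here, exchanging propoxycarbonyl for 1-hydroxypropyl on a double-bonded ring carbon gives an at least 710-fold higher number from compound 2 to compound 3 (2.85 log units; beyond the scatter) in this assay, the only single-place step so far, and it shows that the inhibition of compound 2 depends heavily on the group at this place. Compound 3 reads > 10000 nM, which is a limit of the assay and not a number. The full size of the step therefore stays unknown, and only its minimum can be read: the limit of > 10000 nM in this assay, at which 1 of the 3 values shown sits.

The change alters the carbonyl, the hydroxyl and the chain together, so the compounds shown cannot separate what each contributes. Going by these compounds, whether an amide or a carboxylic acid on this ring carbon would keep the number of compound 2 remains open.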